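One Methoxy Less on the Carbonyl-Side Ring

The source may hold more compounds than are shown below. What is called first, only, known or untested is meant among the compounds shown, and "the series" means these compounds.

For the measured compounds named here, compound 3 `COc1ccc(C(=O)/C=C/c2cc(-c3cc(OC)c(OC)c(OC)c3)n[nH]2)cc1OC` stands lowest of the three numbers measured so far: in a functional assay on NCI-H23 cells (Homo sapiens) for cytotoxicity, read by sulforhodamine B assay, with a stated time of 48 h, tested at 10 uM (on this read-out higher numbers stand for a weaker effect at the one concentration tested and lower numbers for a stronger effect), compound 3 gives -36%. Compound 1 `COc1cc(-c2cc(/C=C/C(=O)c3ccc(N)cc3)[nH]n2)cc(OC)c1OC` gives -19% in this assay, and compound 2 `COc1cc(-c2cc(/C=C/C(=O)c3ccc(Cl)c(Cl)c3)[nH]n2)cc(OC)c1OC` gives 79%. The steps among them all exchange the whole aryl group on the carbonyl carbon: a number 17 percentage points lower from compound 1 to compound 3 (beyond the scatter), a number 98 percentage points higher from compound 1 to compound 2 (beyond the scatter), and a number 115 percentage points lower from compound 2 to compound 3 (beyond the scatter). Compound 4 `COc1ccc(C(=O)/C=C/c2cc(-c3cc(OC)c(OC)c(OC)c3)n[nH]2)cc1` differs from compound 3 by hydrogen in place of methoxy on an aromatic carbon. Going by the values given here, no measured step removes a single methoxy from that ring, so the three steps bear on this change only indirectly; they show that the 3,4-dimethoxyphenyl ring sits at the low end and that a swap to 4-aminophenyl moved the number modestly upward. A smaller change is therefore expected to move the number by at most a modest amount, most likely upward, and possibly not beyond the scatter, giving an expected a number 16 percentage points higher from compound 3 to compound 4 (beyond the scatter). Compound 4 is estimated at -20% in this assay, with a range from -45% to 20%.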

Compound 4, a percentage reported as activity, at one concentration (the size of the read-out at that concentration, not a potency): 2%
Compound 4: the middle estimate sits 22 percentage points below what was measured; the measured number falls inside the stated range.
By their numbers in this assay, from the lowest: compound 3; then compound 1; then compound 4; then compound 2.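

Within this assay, the single methoxy ortho to a methoxy group on the carbonyl-side ring carries real weight: hydrogen in its place gives a number 38 percentage points higher from compound 3 to compound 4 (beyond the scatter), a large step from the loss of one group. With only the 4-methoxyphenyl left, the ring no longer matches the 4-aminophenyl ring on this read-out, since methoxy in place of amino gives a number 21 percentage points higher from compound 1 to compound 4 (beyond the scatter), yet it stays far from the 3,4-dichlorophenyl ring, with a number 77 percentage points lower from compound 2 to compound 4 (beyond the scatter) on that exchange. Nothing available explains why this one group matters so much.

The compounds shown leave open whether a hydroxyl, an ethoxy or a fluorine in that place would hold the lower number. They also leave open whether removing the other methoxy of the 3,4-dimethoxyphenyl ring instead would cost as much.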